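Flipping one stereocentre on a compound already beyond the limit

The source may hold more compounds than are shown below. What is called first, only, known or untested is meant among the compounds shown, and "the series" means these compounds.

Of the compounds shown here, three have been measured in an ADME assay on RAW264.7 cells (Mus musculus) for cytotoxicity, read by MTT assay, with a stated time of 18 h; on this read-out lower numbers stand for higher toxicity in this test and higher numbers for lower toxicity in this test. Compound 1 `C=C1C(=O)OC[C@H]1CCOC(=O)Nc1ccc(C(C)C)cc1` gives 12400 nM in this assay, and compound 2 `C=C1C(=O)OC[C@@H]1CCOC(=O)Nc1ccc(C(C)C)cc1` gives 15300 nM. These two have the same atoms and bonds and differ only in configuration as drawn, and the step of a 1.2-fold higher number from compound 1 to compound 2 (0.09 log units; within the scatter) shows that this flip alone left the read-out within the scatter, which rests on (the fact that compounds 1 and 2 differ only in the configuration as drawn). Compound 3 `C=C1C(=O)OC[C@@H]1CCOC(=O)Nc1c(C)cccc1C(C)C` carries a differently substituted version of the shared core and gives only a limit in this assay, > 50000 nM, so no number is known for it. Compound 4 `C=C1C(=O)OC[C@H]1CCOC(=O)Nc1c(C)cccc1C(C)C` stands to compound 3 as compound 2 stands to compound 1: the two compounds have the same atoms and bonds and differ only in configuration as drawn: 1 of 1 stereo elements differ; a stereocentre at a saturated ring carbon is drawn R in compound 3 and S in compound 4. For the measured compounds named here, the only measured step of the same kind, a 1.2-fold higher number from compound 1 to compound 2 (0.09 log units; within the scatter), was within the scatter, so no step beyond the scatter is expected in this assay for compound 4. Compound 4 is therefore expected to give about 60000 nM in this assay, with a range from 30000 nM to 120000 nM, and most likely again only a limit because compound 3 sits at the limit of > 50000 nM in this assay, at which 1 of the 3 values shown sits. This estimate means a step that the limit leaves unreadable from compound 3 to compound 4 that stays within the scatter.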

Compound 4, half-maximal cytotoxic concentration: 22200 nM
The estimate for compound 4 lay 2.7-fold (0.43 log units) above the measured number; the whole stated range lies above it.
By their numbers in this assay, from the lowest: compounds 1, 2 and 4 (each within the scatter of the next). At a limit, above all of these: compound 3.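

Here the stereocentre at the saturated ring carbon makes a readable difference in this assay: the flip gives an at least 2.2-fold lower number from compound 3 to compound 4 (0.35 log units; beyond the scatter), whereas the same kind of flip on the other pair gave a 1.2-fold higher number from compound 1 to compound 2 (0.09 log units; within the scatter). Compound 3 gives > 50000 nM, which is a limit and not a number, so this step has a known minimum size but no exact one. Since nothing else changes within the pair, the step belongs to the configuration alone: the fact that compounds 3 and 4 differ only in the configuration as drawn

Two pairs cannot settle whether configuration counts in this way only with the substitution pattern of compounds 3 and 4, or why the two pairs differ. The compounds shown also leave open how the same flip behaves when an amine or a carboxylic acid stands on the aromatic ring in place of the alkyl groups.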